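The source may report more compounds than this note shows. Statements on the series, on what has been measured and on what is new or still open speak of the compounds shown alone.

Compound 1 `Cc1ccc(Nc2nc(SCc3cn(Cc4ccccc4Cl)nn3)nc(-c3ccccc3)c2C#N)cc1` gives 3390 nM in a functional assay on B16-F10 cells (Mus musculus) for inhibition, read by MTT assay, with a stated time of 72 h (a higher number here means a weaker inhibitor, a lower number a stronger inhibitor), and compound 2 `Cc1ccc(Nc2nc(SCc3cn(Cc4ccccc4Cl)nn3)nc(-c3ccc(C)cc3)c2C#N)cc1` gives 2630 nM; the step of a 1.3-fold lower number from compound 1 to compound 2 (0.11 log units; within the scatter). Compound 3 `COc1cc(-c2nc(SCc3cn(Cc4ccccc4Cl)nn3)nc(Nc3ccc(C)cc3)c2C#N)cc(OC)c1OC` gives 20300 nM, the highest of the three numbers, reached by the steps of a 6.0-fold higher number from compound 1 to compound 3 (0.78 log units; beyond the scatter) and a 7.7-fold higher number from compound 2 to compound 3 (0.89 log units; beyond the scatter). Compound 4 `Cc1ccc(Nc2nc(SCc3cn(Cc4ccccc4Cl)nn3)nc(-c3ccc(Cl)cc3)c2C#N)cc1` has not yet been measured in this assay. It differs from compound 3 by 4-chlorophenyl in place of 3,4,5-trimethoxyphenyl on an aromatic carbon. The two steps into compound 3 show that a trimethoxyphenyl in place of a phenyl or methylphenyl raised the number modestly; compound 4 undoes that change and carries a ring closer to those of compounds 1 and 2, whose numbers lie near each other. The expected step is therefore a 6.8-fold lower number from compound 3 to compound 4 (0.83 log units; beyond the scatter). Compound 4 is expected to give 3000 nM in this assay, with a range from 1200 nM to 8000 nM.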

Compound 4, half-maximal inhibitory concentration: 4810 nM
For compound 4 the middle estimate is 1.6-fold (0.21 log units) below the measured one, and the stated range covers the measured number.
By their numbers in this assay, from the lowest: compounds 2, 1 and 4 (each within the scatter of the next); then compound 3.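

In this assay, a single ring swap at this position gives a 4.2-fold lower number from compound 3 to compound 4 (0.63 log units; beyond the scatter), so a para-free reading is not needed: the high number of compound 3 goes with the 3,4,5-trimethoxyphenyl group, not with a substituent on this ring as such. Chloro, methyl and hydrogen on the ring cannot be told apart, with a 1.8-fold higher number from compound 2 to compound 4 (0.26 log units; within the scatter) and a 1.4-fold higher number from compound 1 to compound 4 (0.15 log units; within the scatter). Nothing available explains these numbers. Open, on these data alone, is whether a single methoxy group would raise the number as the three together do. Also open, as far as these compounds go, is how an amine or a carboxylic acid on this ring would behave.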